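The source may hold more compounds than are shown below. What is called first, only, known or untested is meant among the compounds shown, and "the series" means these compounds.

Within the data shown here, in a functional assay on HT-29 cells (Homo sapiens) for cytotoxicity, read by MTT assay, with a stated time of 72 h (a higher number here means a weaker inhibitor of growth, a lower number a stronger inhibitor of growth), compound 3 `C=CCOC(=O)Nc1ccc([Se]C#N)cc1` gives 24500 nM, which sets it second highest of the three numbers known: compound 1 `CCCOC(=O)Nc1ccc([Se]C#N)cc1` gives 28400 nM, and compound 2 `O=C(Nc1ccc([Se][Se]c2ccc(NC(=O)OCc3ccccc3)cc2)cc1)OCc1ccccc1` gives 1800 nM. Compound 4 `N#C[Se]c1ccc(NC(=O)Oc2ccccc2)cc1` differs from compound 3 by phenyl in place of allyl on an oxygen next to a carbonyl group. Among the measured compounds shown here, the one measured step touching the same oxygen, a 1.2-fold lower number from compound 1 to compound 3 (0.06 log units; within the scatter), was small and stayed within the scatter. For the measured compounds named here, compound 2 is built differently in more than one place, so its value shows only that much lower numbers occur. Going by the values given here, no measured step covers a phenyl entering at this oxygen, so the expected step of a 1.2-fold lower number from compound 3 to compound 4 (0.09 log units; within the scatter) is none beyond the scatter. Compound 4 is therefore estimated at 20000 nM, with a range from 7000 nM to 55000 nM.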

Compound 4, concentration for 50% growth inhibition: 11700 nM
For compound 4 the middle estimate is 1.7-fold (0.23 log units) above the measured one, and the stated range covers the measured number.
By their numbers in this assay, from the lowest: compound 2; then compound 4; then compounds 3 and 1 (each within the scatter of the next).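

At the oxygen next to a carbonyl group, the earlier change from ethyl to vinyl on the chain stayed within the scatter, but an aromatic ring at this oxygen moves the number beyond it. In this assay there is a 2.1-fold lower number from compound 3 to compound 4 (0.32 log units; beyond the scatter) and also a 2.4-fold lower number from compound 1 to compound 4 (0.39 log units; beyond the scatter) and both steps are modest. Nothing available explains why the phenyl group has this effect.

The compounds shown leave open whether a cyclohexyl group, a saturated ring, would match phenyl here. They also leave open how a longer chain or a phenyl ring carrying an amine would fare.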